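Notes on the shared core: efficacy at the dopamine D4 receptor

A few compounds are considered here, and "the series" means these few. Any claim that something is new, unique, unknown or untested is made for them only; others in the source may bear on it.

Measured compounds:
compound 1, `Cc1cccc(NC(=O)CN2CCC(c3ccc(O)cc3)CC2)c1`, 60%
compound 2, `Cc1cccc(NC(=O)CN2CCC(c3cccc(O)c3)CC2)c1`, 66%
compound 3, `CCOc1cccc(C(=O)NCN2CCC(c3cccc[n+]3[O-])CC2)c1`, 54%

In a functional assay on HEK293 cells for agonist activity at D(4) dopamine receptor (Homo sapiens), read by FLIPR (on this read-out higher numbers stand for larger maximal responses and lower numbers for smaller maximal responses), compound 2 gives the highest of the three numbers, with compound 1 lying nearest at 60%, a gap within the scatter, and compound 3 furthest at 54%, a gap beyond the scatter. Compound 4, `Cc1cccc(NC(=O)CN2CCC(c3ccccc3F)CC2)c1`, has not been measured. It differs from compound 2 in one place: 2-fluorophenyl in place of 3-hydroxyphenyl on a saturated ring carbon. Within the data shown here, the only measured step that touches the same site is a number 6 percentage points higher from compound 1 to compound 2 (within the scatter), which moved the hydroxyl without removing it. Among the measured compounds shown here, no measured step removes the hydrogen-bond donor and acceptor or introduces fluorine, and compound 3 differs from the others in several places at once, so only its value is known. The change to compound 4 is therefore expected to give a step of a number 8 percentage points lower from compound 2 to compound 4 (within the scatter), at most a small decrease, with wide uncertainty. Compound 4 is estimated at 58%, ranging from 40% to 75%.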

Compound 4, largest response reached (reported as efficacy), in percent of the reference or control that the assay uses: 57%
Compound 4: the middle estimate sits 1 percentage points above what was measured; measured number inside the range.
By their numbers in this assay, from the lowest: compounds 3, 4, 1 and 2 (each within the scatter of the next, the first and the last beyond it).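

In this assay, replacing the hydroxylated aryl group with 2-fluorophenyl gives a number 9 percentage points lower from compound 2 to compound 4 (within the scatter) and a number 3 percentage points lower from compound 1 to compound 4 (within the scatter). At this saturated ring carbon, therefore, a hydroxyl on the aryl group is not required for a maximal response of this size: the entering group has 0 hydrogen-bond donors and 0 hydrogen-bond acceptors, yet neither step leaves the scatter. Nothing available explains this tolerance.

From the compounds shown here alone, it remains open whether this tolerance extends to unsubstituted phenyl, a methoxyphenyl or an aminophenyl at the same carbon, or to a larger group such as naphthyl. The compounds shown also leave open whether the same exchange on the core of compound 2 would hold up with a different amide portion, such as the ethoxybenzamide of compound 3.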